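A few compounds are considered here, and "the series" means these few. Any claim that something is new, unique, unknown or untested is made for them only; others in the source may bear on it.

Of the compounds shown here, three sharing one core have been measured so far in a functional assay on A549 cells (Homo sapiens) for antiproliferative activity, read by MTT assay, with a stated time of 72 h (a lower number here means a stronger inhibitor, a higher number a weaker inhibitor), and they give a first sense of scale. Compound 2 `O=C(N/N=C/c1ccc(Br)cc1)Nc1ccc(Oc2ccnc3[nH]ccc23)cc1` reads 640 nM and sits close to compound 1 `O=C(N/N=C/c1ccc(Br)cc1)Nc1ccc(Oc2ccnc3[nH]ccc23)c(F)c1` at 820 nM as its near neighbour, while compound 3 `COc1ccc(/C=N/NC(=O)Nc2ccc(Oc3ccnc4[nH]ccc34)cc2)c(OC)c1OC` at 3340 nM has a clearly higher number. Going by the values given here, the only measured single change is a 1.3-fold lower number from compound 1 to compound 2 (0.11 log units; within the scatter) as hydrogen replaces fluoro on an aromatic carbon, and it stays within the scatter. That change lies elsewhere in the molecule, so it offers little guidance here. Compound 4 `O=C(N/N=C/c1ccc(O)cc1Br)Nc1ccc(Oc2ccnc3[nH]ccc23)cc1` instead differs from compound 2 on a carbon with a double bond to nitrogen, as follows: 2-bromo-4-hydroxyphenyl in place of 4-bromophenyl on a carbon with a double bond to nitrogen is the full change. Among the compounds with values here, no measured step covers this swap. Within the data shown here, the only hint is compound 3 at 3340 nM with another group on that carbon and a weaker result. A modest rise is therefore expected, and the estimate is a 1.9-fold higher number from compound 2 to compound 4 (0.27 log units; within the scatter) near the edge of the scatter. In this assay the estimate for compound 4 is 1200 nM with an expected range from 400 nM to 3600 nM around it.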

Compound 4, half-maximal inhibitory concentration: 5080 nM
Compound 4: middle estimate off by 4.2-fold (0.63 log units), on the low side, and the stated range ends below it.
By their numbers in this assay, from the lowest: compounds 2 and 1 (each within the scatter of the next); then compounds 3 and 4 (each within the scatter of the next).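

The carbon with a double bond to nitrogen proves to be a sensitive place in this assay: replacing 4-bromophenyl with 2-bromo-4-hydroxyphenyl gives a 7.9-fold higher number from compound 2 to compound 4 (0.90 log units; beyond the scatter), a step beyond the scatter. The entering group keeps the ring and the bromine, so their presence alone does not preserve the lower number, and compound 2 at 640 nM remains below both compound 3 at 3340 nM and compound 4 at 5080 nM as this group varies. Nothing available here explains the rise.

Compound 4 differs from compound 2 in both the place of the bromine and the added hydroxyl, so the two contributions cannot be separated. The compounds shown include neither 2-bromophenyl nor 4-hydroxyphenyl, the two groups that would each carry only one of these differences.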